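The source may hold more compounds than are shown below. What is called first, only, known or untested is meant among the compounds shown, and "the series" means these compounds.

Compound 2 `Cc1nccc(N2c3ccc(C4(NC(=O)c5ccc(F)cc5)CC4)cc3[C@H]3CC[C@H]32)n1` gives 64 nM in an assay on blood for inhibition of Indoleamine 2,3-dioxygenase 1 (Homo sapiens); a lower number here means a stronger inhibitor, a higher number a weaker inhibitor.
Compound 1 `O=C(Nc1ccc(Cl)cc1)C1(c2ccc3c(c2)CCN3c2ccccn2)CCC1` gives 640 nM in this assay.

Of these two numbers, compound 2 has the lower one, and compound 1 stands a step away that is beyond the usual scatter. Compound 3 `Cc1nccc(N2c3ccc(C4(NC(=O)c5ccc(F)cc5)CC4)cc3[C@@H]3CC[C@@H]32)n1` has not been measured. It differs from compound 2 in this way: the two compounds have the same atoms and bonds and differ only in configuration as drawn: 2 of 2 stereo elements differ (all stereocentres are inverted: mirror images); a stereocentre at a saturated ring carbon is drawn R in compound 2 and S in compound 3; a stereocentre at a saturated ring carbon is drawn R in compound 2 and S in compound 3. Going by the values given here, no measured pair shows what inverting both stereocentres does here, so no guide exists. Mirror images often differ in potency, and compound 2 is the better of the two known compounds, so compound 3 is expected to be weaker, with the step from compound 2 to compound 3 estimated as a 6.3-fold higher number from compound 2 to compound 3 (0.80 log units; beyond the scatter). For compound 3 the expected value is 400 nM, ranging from 60 nM to 3000 nM.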

Compound 3, half-maximal inhibitory concentration: 66 nM
Beside the measured number, compound 3's estimate is 6.1-fold (0.78 log units) above it; measured number inside the range.
By their numbers in this assay, from the lowest: compounds 2 and 3 (each within the scatter of the next); then compound 1.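

In this assay, inverting both stereocentres gives a 1.0-fold higher number from compound 2 to compound 3 (0.01 log units; within the scatter), so at these two saturated ring carbons the drawn configuration leaves no readable mark on the number. Going by these compounds alone, this is the first pair here that differs in only one place, which makes the comparison clean: the fact that compounds 2 and 3 differ only in the configuration as drawn. The compounds shown leave open whether this indifference to configuration would persist with other groups, such as an amine or a carboxylic acid in place of the fluorine. They also cannot say why the two mirror images give such close numbers.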